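Benzylsulfanyl ring substituent survey: outlook for compound 4

A few compounds are considered here, and "the series" means these few. Any claim that something is new, unique, unknown or untested is made for them only; others in the source may bear on it.

Measured in a functional assay on DU-145 cells (Homo sapiens) for cytotoxicity, read by MTT assay; a higher number here means a weaker inhibitor, a lower number a stronger inhibitor:
compound 1 `COc1ccc2cc([C@H](C)c3nnc(SCc4ccc(F)cc4)n3-c3ccc(F)cc3)ccc2c1`: 60200 nM
compound 2 `COc1cccc(CSc2nnc([C@@H](C)c3ccc4cc(OC)ccc4c3)n2-c2ccc(F)cc2)c1`: 19200 nM
compound 3 `COc1ccc(CSc2nnc([C@@H](C)c3ccc4cc(OC)ccc4c3)n2-c2ccc(F)cc2)cc1`: a limit, <= 400000 nM

Compound 3 stands only at a limit of this assay, (the limit of <= 400000 nM in this assay, at which 1 of the 3 values shown sits); no number is known for it. The change to compound 4 `COc1ccc2cc([C@H](C)c3nnc(SCc4ccc(Cl)cc4)n3-c3ccc(F)cc3)ccc2c1` is chloro in place of methoxy on an aromatic carbon. Among the measured compounds shown here, only one measured step is readable: a 3.1-fold lower number from compound 1 to compound 2 (0.50 log units; beyond the scatter). The steps a step that the limit leaves unreadable from compound 1 to compound 3 and a step that the limit leaves unreadable from compound 2 to compound 3 cannot be sized. Compound 1, which carries 4-fluorophenyl at the same position, gives 60200 nM in this assay, and a 4-chlorophenyl is the closest measured analogue to that. The expected step is therefore a step that the limit leaves unreadable from compound 3 to compound 4, from the limit into readable territory. Compound 4 is estimated at 55000 nM, with a range from 15000 nM to 250000 nM.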

Compound 4, half-maximal inhibitory concentration: 57400 nM
The estimate for compound 4 lay 1.0-fold (0.02 log units) below the measured number; low and high end bracket the measured number.
By their numbers in this assay, from the lowest: compound 2; then compounds 4 and 1 (each within the scatter of the next).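

In this assay, chloro in place of fluoro on this aromatic carbon gives no readable difference: a 1.0-fold lower number from compound 1 to compound 4 (0.02 log units; within the scatter). 4-Chlorophenyl in place of 3-methoxyphenyl gives a 3.0-fold higher number from compound 2 to compound 4 (0.48 log units; beyond the scatter), so compound 2 stays apart from both halogen-bearing compounds. Compound 3 remains a limit, and the steps to it cannot be read: the limit of <= 400000 nM in this assay, at which 1 of the 4 values shown sits.

As far as these compounds go, whether 4-methoxybenzyl differs from 4-chlorobenzyl at this position stays open. Also open, from the compounds shown here alone, is what an amine or a carboxylic acid on this aromatic carbon would give in this assay.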